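This account rests on a few compounds, and the source may have more. Where it says the series, first, only, none or still open, it means among the compounds named here.

Compound 1 `COc1cc2ncnc(Nc3ccc(F)c(Cl)c3)c2cc1OCCCCC(=O)Nc1ccc(S(N)(=O)=O)cc1` stands lowest of the two numbers measured in a functional assay on A-431 cells (Homo sapiens) for antiproliferative activity, read by MTT assay, with a stated time of 72 h (a higher number here means a weaker inhibitor, a lower number a stronger inhibitor), giving 5020 nM. Compound 2 `COc1cc2ncnc(Nc3ccc(Br)cc3)c2cc1OCCCCC(=O)Nc1ccc(S(N)(=O)=O)cc1` gives 6570 nM in this assay, and the step of a 1.3-fold higher number from compound 1 to compound 2 (0.12 log units; within the scatter) lies within the scatter. Compound 3 `COc1cc2ncnc(Nc3ccc(OCc4cccc(F)c4)c(Cl)c3)c2cc1OCCCCC(=O)Nc1ccc(S(N)(=O)=O)cc1` differs from compound 1 by (3-fluorobenzyl)oxy in place of fluoro on an aromatic carbon. Within the data shown here, the only measured step, a 1.3-fold higher number from compound 1 to compound 2 (0.12 log units; within the scatter), concerns a different place and is small, so it offers no direct guide. Compound 3 is therefore expected to give a number near that of compound 1, with the step of a 1.7-fold lower number from compound 1 to compound 3 (0.22 log units; within the scatter), and its estimate in this assay is 3000 nM, in the range 600 nM to 15000 nM.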

Compound 3, half-maximal inhibitory concentration: 7790 nM
Estimate against measurement, compound 3: 2.6-fold (0.41 log units) below; measured number inside the range.
By their numbers in this assay, from the lowest: compounds 1, 2 and 3 (each within the scatter of the next).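

At this aromatic carbon, ortho to a chloro group and para to a large group, (3-fluorobenzyl)oxy replaces fluoro, bringing 9 heavy atoms and a six-membered aromatic ring, with a 1.6-fold higher number from compound 1 to compound 3 (0.19 log units; within the scatter) in this assay. The position therefore tolerates a far larger group without a change beyond the scatter, which the earlier step at a different place could not show. No evidence available here explains this result. On these data alone, whether an amine, a carboxylic acid or an unsubstituted benzyloxy group would behave alike at this position remains open.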